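The source may hold more compounds than are shown below. What is called first, only, known or untested is meant among the compounds shown, and "the series" means these compounds.

In a functional assay on NCI-H460 cells (Homo sapiens) for cytotoxicity, read by MTT assay, with a stated time of 72 h (on this read-out lower numbers stand for stronger inhibition and higher numbers for weaker inhibition), compound 1 `CN(C)CCNc1nc(-c2ccc(NC(=O)Nc3ccc(Cl)cc3Cl)cc2)nc2ccsc12` gives 1650 nM, and its partner compound 2 `Cc1ccc(NC(=O)Nc2ccc(-c3nc(NCCN(C)C)c4sccc4n3)cc2)cc1` gives 1880 nM. The two are related by one change, (4-methylphenyl in place of 2,4-dichlorophenyl on an amide-type nitrogen), and that change made a step of a 1.1-fold higher number from compound 1 to compound 2 (0.06 log units; within the scatter). Compound 3 `CCN(CC)CCCNc1nc(-c2ccc(NC(=O)Nc3ccc(Cl)cc3Cl)cc2)nc2c(Cl)c(Cl)sc12` carries a different core, and how its core differs from that of compound 1 is not broken down here; in this assay compound 3 gives 1170 nM. Compound 4 `CCN(CC)CCCNc1nc(-c2ccc(NC(=O)Nc3ccc(C)cc3)cc2)nc2c(Cl)c(Cl)sc12` is not yet measured and differs from compound 3 by 4-methylphenyl in place of 2,4-dichlorophenyl on an amide-type nitrogen, which is the same change as that from compound 1 to compound 2, occurring twice among these compounds, at the same place. Because the earlier step of a 1.1-fold higher number from compound 1 to compound 2 (0.06 log units; within the scatter) stayed within the scatter, a similar step is expected here, estimated as a 1.1-fold higher number from compound 3 to compound 4 (0.05 log units; within the scatter). Compound 4 is therefore expected to give about 1300 nM in this assay, most likely between 650 nM and 2600 nM.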

Compound 4, half-maximal inhibitory concentration: 1240 nM
Compound 4: middle estimate off by 1.0-fold (0.02 log units), on the high side; the measured number falls inside the stated range.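

In this assay, putting 4-methylphenyl in place of 2,4-dichlorophenyl on the amide-type nitrogen gave a 1.1-fold higher number from compound 3 to compound 4 (0.03 log units; within the scatter), and this step agrees with the one seen on the other core: the same change on two cores in this assay, a 1.1-fold higher number (0.06 log units; within the scatter) from compound 1 to compound 2 and a 1.1-fold higher number (0.03 log units; within the scatter) from compound 3 to compound 4, 1.1-fold (0.03 log units) apart, within the scatter of two such steps Across these two pairs, then, the change carried from one core to the other and left the number within the scatter each time. Among these compounds, this shows only that the change made no readable difference on these two cores; it does not show that the same would hold on any other core, or that a step beyond the scatter would carry over in the same way.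

Going by these compounds, it remains open whether a 4-carboxyphenyl or a cyclohexyl group on that nitrogen would leave the number similarly unchanged. On these data alone, whether the same holds in other cell lines also remains open.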